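Cytotoxicity in HEK293 cells: replacing a dichlorophenyl group

The source may report more compounds than this note shows. Statements on the series, on what has been measured and on what is new or still open speak of the compounds shown alone.

Of the compounds shown here, two built on a shared core have been tested in an ADME assay on HEK293 cells (Homo sapiens) for cytotoxicity, read by MTT assay, with a stated time of 48 h; a lower number here means a stronger inhibitor, a higher number a weaker inhibitor. Compound 1 `COc1ccc(-c2nc(C)c(C(=O)CSc3nc(-c4ccc(OC)c(OC)c4)c(C#N)c(=O)[nH]3)s2)cc1` gives 23300 nM in this assay. Compound 2 `Cc1nc(-c2ccccc2)sc1C(=O)CSc1nc(-c2ccc(Cl)c(Cl)c2)c(C#N)c(=O)[nH]1` gives 85100 nM in this assay, the highest of the two numbers and beyond the usual scatter from compound 1. Among the measured compounds shown here, no single-point step between the two measured compounds is available, so compound 1 only shows what a compound carrying a 3,4-dimethoxyphenyl group can give in this assay.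

Compound 3 `COc1ccc(-c2nc(SCC(=O)c3sc(-c4ccccc4)nc3C)[nH]c(=O)c2C#N)cc1OC` has not yet been measured. It differs from compound 2 in one place: 3,4-dimethoxyphenyl in place of 3,4-dichlorophenyl on an aromatic carbon. Because compound 1, which also carries a 3,4-dimethoxyphenyl group, gives 23300 nM, a modest step downward in this assay is expected, a 1.9-fold lower number from compound 2 to compound 3 (0.28 log units; within the scatter), possibly no more than the scatter. Compound 3 is therefore estimated at 45000 nM in this assay, within a range from 15000 nM to 120000 nM.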

Compound 3, half-maximal inhibitory concentration: 91800 nM
Compound 3: middle estimate off by 2.0-fold (0.31 log units), on the low side, and the stated range covers the measured number.
By their numbers in this assay, from the lowest: compound 1; then compounds 2 and 3 (each within the scatter of the next).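

In this assay, 3,4-dimethoxyphenyl in place of 3,4-dichlorophenyl on this aromatic carbon, ortho to the cyano group, gives a 1.1-fold higher number from compound 2 to compound 3 (0.03 log units; within the scatter), so the shown results do not separate these two groups at this position. Hydrogen in place of methoxy on an aromatic carbon elsewhere in the molecule gives a 3.9-fold higher number from compound 1 to compound 3 (0.60 log units; beyond the scatter), which shows that the lower number of compound 1 does not come with 3,4-dimethoxyphenyl alone. Nothing on hand explains either step.

Going by these compounds, it remains open how an amine or a carboxylic acid would read in place of these aromatic groups at this position. On these data alone, it is also open whether the methoxy step would stay the same size on a compound carrying 3,4-dichlorophenyl.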